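The compounds below may be only part of what the source reports. "The series", "measured", "known", "first", "only" and "open" are said of these compounds alone.

Compound 1 `Cc1cc(Nc2nc(NCc3ccccc3)nc3[nH]ncc23)n[nH]1` gives 1960 nM in an assay on isolated protein for inhibition of serine/threonine-protein kinase PAK 4 (Homo sapiens), read by HTRF, with a stated time of 60 min (a higher number here means a weaker inhibitor, a lower number a stronger inhibitor), the higher of the two numbers recorded so far. Compound 2 `Cc1cc(Nc2nc(NCc3cccc(Cl)c3)nc3[nH]ncc23)n[nH]1` gives 611 nM in this assay, and the step of a 3.2-fold lower number from compound 1 to compound 2 (0.51 log units; beyond the scatter) is modest but beyond the scatter. Compound 3 `Cc1cc(Nc2nc(NCc3cccc(Br)c3)nc3[nH]ncc23)n[nH]1` differs from compound 1 by bromo in place of hydrogen on an aromatic carbon. Only the chloro step bears on this change, and a halogen of the same kind at the same place makes a similar fall in number the natural expectation. Compound 3 is therefore estimated at 500 nM in this assay, between 200 nM and 1200 nM, meaning an expected step of a 3.9-fold lower number from compound 1 to compound 3 (0.59 log units; beyond the scatter).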

Compound 3, half-maximal inhibitory concentration: 4340 nM
For compound 3 the middle estimate is 8.7-fold (0.94 log units) below the measured one; measured number outside the range, above it.
By their numbers in this assay, from the lowest: compound 2; then compound 1; then compound 3.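

At this aromatic carbon in this assay, the two halogens part in direction: bromo gives a 2.2-fold higher number from compound 1 to compound 3 (0.35 log units; beyond the scatter) rather than the fall seen with chloro, and exchanging chloro for bromo gives a 7.1-fold higher number from compound 2 to compound 3 (0.85 log units; beyond the scatter) as the larger step. The gain from chloro therefore does not carry over to bromo, so this place does not treat the two halogens alike. Nothing available accounts for this difference.

Open, going by these compounds, is where fluoro, methyl, methoxy or an amine would fall at this place, and whether chloro and bromo would part the same way elsewhere on the ring.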